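The compounds below may be only part of what the source reports. "The series", "measured", "known", "first", "only" and "open" are said of these compounds alone.

The series is small. Among the measured compounds shown here, in a toxicity assay on NIH3T3 cells (Mus musculus) for cytotoxicity, read by resazurin assay (on this read-out lower numbers stand for an effect already at smaller amounts and higher numbers for an effect only at larger amounts of compound), compound 1 `c1ccc(-c2ccc(Cn3cncc3CNc3cccc(-c4ccccc4)c3)cc2)cc1` gives 10000 nM, the only exact number among the three compounds measured. Compound 2 `O=C(c1ccc(NCc2cncn2Cc2ccc(-c3ccccc3)cc2)cc1-c1ccccc1)N1CCCCC1` reads > 1000 nM, which is a limit of the assay. Compound 3 `CCOC(=O)c1ccc(NCc2cncn2Cc2ccc(-c3ccccc3)cc2)cc1-c1ccccc1` reads > 10000 nM, which is also a limit.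

Compound 4 `c1ccc(Cn2cncc2CNc2cccc(-c3ccccc3)c2)cc1` keeps the rest of compound 1 but loses a phenyl group: hydrogen in place of phenyl on an aromatic carbon. In words, this is hydrogen in place of phenyl on an aromatic carbon.

The measured steps offer little guidance. There is a step that the limit leaves unreadable from compound 1 to compound 2, and there is a step that the two limits leave unreadable from compound 2 to compound 3. Neither has a readable size, and neither removes this phenyl group. The only direction comes from a number no lower from compound 1 to compound 3 (the limit leaves the size open), and that change also lies elsewhere on the molecule. For the measured compounds named here, with no measured step at this place, a large move in either direction cannot be supported, so little or no change beyond the scatter is expected, with a slight tilt toward higher numbers. In this assay, the expected step is a 1.5-fold higher number from compound 1 to compound 4 (0.18 log units; within the scatter). For compound 4, the estimated value is 15000 nM. The expected range for compound 4 runs from 5000 nM to 40000 nM, and a report of only a limit would not be surprising.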

Compound 4, half-maximal effective concentration: > 750 nM
Compound 4 gave a limit, no number; the forecaster's own chance of this, stated with the estimate: 45%; the middle value is on the limit's open side.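

In this assay, compound 4 reads > 750 nM, which is a limit of the assay and not a number. No size can be read for the step from compound 1 to compound 4. The compounds shown leave open whether hydrogen in place of phenyl on this aromatic carbon shifts the number at all, and in which direction.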